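The compounds below may be only part of what the source reports. "The series", "measured", "known", "first", "only" and "open" are said of these compounds alone.

Measured compounds in a functional assay on A549 cells (Homo sapiens) for inhibition, read by MTT assay, with a stated time of 72 h; a lower number here means a stronger inhibitor, a higher number a weaker inhibitor:
- compound 1, `COc1cc2c(Oc3ccc(NC(=O)c4nn(-c5ccccc5)cc(C)c4=O)cc3F)ccnc2cc1OCCCC(=O)NO`: 1900 nM
- compound 2, `COc1cc2c(Oc3ccc(NC(=O)c4nn(-c5ccccc5)ccc4=O)cc3)ccnc2cc1OCCCC(=O)NO`: 9260 nM
- compound 3, `COc1cc2c(Oc3ccc(NC(=O)c4nn(-c5ccc(C)cc5)cc(C)c4=O)cc3)ccnc2cc1OCCCCCCC(=O)NO`: 160 nM

Compound 3 gives the lowest of the three numbers in this assay. Its nearest neighbour is compound 1, and that gap already lies beyond the scatter; the gap to compound 2 is wider still. Compound 3 thus stands apart from both on the numbers shown, though the three differ in more than one place and no single-point step between them is available.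

Compound 4, `COc1cc2c(Oc3ccc(NC(=O)c4nn(-c5ccccc5C)cc(C)c4=O)cc3)ccnc2cc1OCCCCCCC(=O)NO`, is not yet measured. It differs from compound 3 as follows: 2-methylphenyl in place of 4-methylphenyl on an aromatic nitrogen. The same atoms are present, joined differently. Within the data shown here, nothing among the measured compounds isolates this change, so the expectation rests on the size of the change itself, a shift of one methyl within the same aryl group. The expected step of a 1.6-fold higher number from compound 3 to compound 4 (0.21 log units; within the scatter) is taken as small, if anything a slight weakening, and not clearly beyond the scatter. Compound 4 is accordingly expected to give 260 nM in this assay, with a range from 80 nM to 850 nM.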

Compound 4, half-maximal inhibitory concentration: 3130 nM
Compound 4: middle estimate off by 12-fold (1.08 log units), on the low side; the whole stated range lies below it.
By their numbers in this assay, from the lowest: compound 3; then compounds 1 and 4 (each within the scatter of the next); then compound 2.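

In this assay, the aryl group on the aromatic nitrogen proves sensitive to where its methyl sits: 2-methylphenyl in place of 4-methylphenyl gives a 20-fold higher number from compound 3 to compound 4 (1.29 log units; beyond the scatter), although the atoms present are the same. The earlier compounds shown here carried only phenyl or 4-methylphenyl here and also differed from one another elsewhere, so they gave no clean reading of this position. Nothing available bears on the origin of this step.

Still open, on these data alone, is how a plain phenyl group would read on the scaffold of compound 3, so it cannot be said whether the step reflects a gain from 4-methylphenyl, a loss from 2-methylphenyl, or both. Also open, as far as these compounds go, is whether a chlorine or a methoxy group in place of the methyl of compound 4 would read the same way.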